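Piperazine aryl variation: pyridin-3-yl to 3-fluorophenyl

This account rests on a few compounds, and the source may have more. Where it says the series, first, only, none or still open, it means among the compounds named here.

Measured so far in a functional assay on CHO cells with adenosine receptor A1 (Homo sapiens) as the target, read by cAMP accumulation and immunoassay, with a stated time of 6 min, tested at 0.01 uM; on this read-out lower numbers stand for a stronger effect and higher numbers for a weaker effect at the one concentration tested:
- compound 1, `Nc1scc(CN2CCN(c3cc(Cl)cc(Cl)c3)CC2)c1C(=O)c1ccc(Cl)cc1`, -1%
- compound 2, `Nc1scc(CN2CCN(c3cccc(C(F)(F)F)c3)CC2)c1C(=O)c1ccc(Cl)cc1`, -8.2%
- compound 3, `Nc1scc(CN2CCN(c3cccnc3)CC2)c1C(=O)c1ccc(Cl)cc1`, 3.2%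

Compound 3 has the highest number of the three. For the measured compounds named here, its nearest neighbour is compound 1, a number 4.2 percentage points higher from compound 1 to compound 3 (within the scatter); the furthest is compound 2, a number 11.4 percentage points higher from compound 2 to compound 3 (beyond the scatter), the only step in the set that lies beyond the scatter. Between compound 1 and compound 2 the change is a number 7.2 percentage points lower from compound 1 to compound 2 (within the scatter).

Compound 4, `Nc1scc(CN2CCN(c3cccc(F)c3)CC2)c1C(=O)c1ccc(Cl)cc1`, differs from compound 3 in one place: 3-fluorophenyl in place of pyridin-3-yl on an amine nitrogen in a ring. The change runs opposite to the steps into compound 3, where a carbon-only six-membered ring gave way to the pyridine. Both earlier steps, from compound 1 and from compound 2, gave higher numbers on arrival at compound 3, one within and one beyond the scatter. Returning to a carbon-only ring is therefore expected to bring a lower number, at most of modest size, possibly within the scatter: the expected step is a number 6.2 percentage points lower from compound 3 to compound 4 (within the scatter). Compound 4 is estimated at -3%, with a range from -13% to 7%.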

Compound 4, a percentage reported as activity, at one concentration (the size of the read-out at that concentration, not a potency): -18%
Compound 4: the middle estimate sits 15 percentage points above what was measured; the whole stated range lies above it.
By their numbers in this assay, from the lowest: compounds 4, 2, 1 and 3 (each within the scatter of the next, the first and the last beyond it).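

In this assay, the pyridin-3-yl group now stands apart from a further carbon-only ring (a number 21.2 percentage points lower from compound 3 to compound 4 (beyond the scatter)), and 3-fluorophenyl also separates from 3,5-dichlorophenyl (a number 17 percentage points lower from compound 1 to compound 4 (beyond the scatter)), so a change between carbon-only rings on this amine nitrogen can itself go beyond the scatter, which compounds 1 and 2 did not show. Fluoro in place of trifluoromethyl stays inside the scatter (a number 9.8 percentage points lower from compound 2 to compound 4 (within the scatter)), so compound 2 and compound 4 cannot be ordered. No available evidence accounts for these steps.

The step from pyridin-3-yl changes the ring atom and adds fluoro at once, so the two changes cannot be told apart here. On these data alone, how an unsubstituted phenyl ring, or a methoxy or amino group on the aryl ring, would read in this assay stays open.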